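Swapping the core's ethyl for a benzyloxymethyl arm

A few compounds are considered here, and "the series" means these few. Any claim that something is new, unique, unknown or untested is made for them only; others in the source may bear on it.

Of the compounds shown here, three share one core and have been tested in a functional assay on CHOK cells for antagonist activity at growth hormone secretagogue receptor type 1 (Homo sapiens), read by calcium flux; on this read-out higher numbers stand for weaker inhibition and lower numbers for stronger inhibition. Compound 1 `CCc1nc(N)nc(N)c1-c1ccc(NCc2ccc(S(C)(=O)=O)cc2)cc1` gives 12 nM. Compound 2 `CCc1nc(N)nc(N)c1-c1ccc(NCc2ccc(C(C)=O)cc2)cc1` gives 110 nM, and compound 3 `CCc1nc(N)nc(N)c1-c1ccc(NCc2ccnc(Cl)c2)cc1` gives 220 nM. Among these numbers compound 2 holds the second highest place; its nearest neighbour is compound 3, whose number sits within the scatter of its own, while compound 1 sits furthest away, with a clearly lower number.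

The unmeasured compound 4 `CC(=O)c1ccc(CNc2ccc(-c3c(N)nc(N)nc3COCc3ccccc3)cc2)cc1` keeps the acetylphenyl side of compound 2 and alters the core instead: benzyloxy in place of methyl on a saturated chain carbon bound to an aromatic carbon. Taken one bond further out, this reads as ethyl to (benzyloxy)methyl.

Neither measured step touches this part of the molecule. The step of a 9.2-fold higher number from compound 1 to compound 2 (0.96 log units; beyond the scatter) and the step of a 2.0-fold higher number from compound 2 to compound 3 (0.30 log units; within the scatter) both change the group hanging from the nitrogen on the aromatic ring, not the chain on the core. Among the compounds with values here, there is therefore no measured step that bears directly on the move from compound 2 to compound 4, and the expected size of the step in this assay rests on no comparison at all. With nothing to anchor it, compound 4 is expected to give about 150 nM, with an estimated range from 30 nM to 800 nM. This estimate means an expected step of a 1.4-fold higher number from compound 2 to compound 4 (0.13 log units; within the scatter).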

Compound 4, half-maximal inhibitory concentration: 10 nM
Compound 4: middle estimate off by 15-fold (1.18 log units), on the high side; the measured number lies below the stated range.
By their numbers in this assay, from the lowest: compounds 4 and 1 (each within the scatter of the next); then compounds 2 and 3 (each within the scatter of the next).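

On the core, every earlier compound carried the same ethyl, so nothing yet showed whether this chain mattered. Changing it to (benzyloxy)methyl gives an 11-fold lower number from compound 2 to compound 4 (1.04 log units; beyond the scatter) in this assay, which shows that the chain on the core, and not only the group on the nitrogen, can strongly shift this read-out, and that a much larger group carrying an aromatic ring and an oxygen is compatible with stronger inhibition here. Nothing available explains why this step is so large.

The compounds shown leave open which part of the new arm goes with the gain: a methoxymethyl chain would keep the oxygen without the ring, while a 3-phenylpropyl chain would keep the ring with carbon in place of the oxygen. Going by these compounds, it also remains open whether the same change on the core would give a step of similar size with a methylsulfonyl group on the other side of the molecule, as in compound 1.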